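The source may hold more compounds than are shown below. What is called first, only, known or untested is meant among the compounds shown, and "the series" means these compounds.

In a functional assay on HEK-EM293 cells for agonist activity at Thyrotropin receptor (Homo sapiens), read by ELISA and cAMP accumulation, with a stated time of 1 h (on this read-out higher numbers stand for an effect only at larger amounts of compound and lower numbers for an effect already at smaller amounts), compound 3, with the structure `COc1ccc(C2Nc3ccccc3C(=O)N2Cc2ccccc2)cc1COc1ccccc1`, gives 2570 nM. Going by the values given here, of the three compounds measured so far this is the highest number. Compound 2, with the structure `CC(=O)Nc1ccc(OCc2cccc(C3Nc4ccccc4C(=O)N3Cc3ccccc3)c2)cc1`, gives 1860 nM in this assay, which lies within the scatter of the value of compound 3, so the two cannot be told apart. Among the compounds with values here, compound 1, with the structure `COc1ccc(C2Nc3cccc(F)c3C(=O)N2Cc2ccccc2)cc1COc1ccc(NC(C)=O)cc1`, gives 280 nM in this assay, a clearly lower number than that of compound 3, beyond the scatter; compound 1 differs from compound 3 in more than one place, so no single step can be drawn from it.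

Compound 4, with the structure `COc1ccc(C2Nc3ccccc3C(=O)N2Cc2ccccc2)cc1COc1cccc(NC(C)=O)c1`, differs from compound 3 in one place: acetamido in place of hydrogen on an aromatic carbon. Compounds 1 and 2, which both carry an acetamido group, give the lower numbers, while compound 2 is not separated from compound 3 by more than the scatter, so the evidence for a gain is mixed. Compound 4 is therefore expected to show a step of a 2.1-fold lower number from compound 3 to compound 4 (0.33 log units; beyond the scatter) from compound 3, a modest move toward a lower number that may or may not exceed the scatter. The value for compound 4 in this assay is estimated at 1200 nM, with a range from 350 nM to 4000 nM.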

Compound 4, half-maximal effective concentration: 4340 nM
Beside the measured number, compound 4's estimate is 3.6-fold (0.56 log units) below it; measured number above the stated range.
By their numbers in this assay, from the lowest: compound 1; then compounds 2, 3 and 4 (each within the scatter of the next, the first and the last beyond it).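

In this assay, going by these compounds alone, the change of hydrogen to acetamido on an aromatic carbon of the phenoxy ring, meta to a large group, gives a 1.7-fold higher number from compound 3 to compound 4 (0.23 log units; within the scatter) and so provides the first step that can be read at a single place, with compound 3 and compound 4 not told apart at this position. The acetamido group at this place therefore brings no separable change on the core of compound 3, while compound 1 differs from compound 4 in more than one place, so its value cannot be credited to the acetamido group alone. No measurement at hand accounts for this result.

The compounds shown leave open whether an amine or a carboxylic acid on this same aromatic carbon, or a chain longer than acetamido, would give a step beyond the scatter. They also leave open what the acetamido group does at other places on this ring, and what the fluorine on the core of compound 1 contributes on its own.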